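A few compounds are considered here, and "the series" means these few. Any claim that something is new, unique, unknown or untested is made for them only; others in the source may bear on it.

Measured compounds:
- compound 1, `COC(=O)c1ccc(-n2cc(CCCOS(=O)(=O)c3ccc(-c4ccccc4)cc3)nn2)cc1`: "not determined" (no result reported)
- compound 2, `Cc1ccc(-n2cc(CCCOS(=O)(=O)c3ccc(C)cc3)nn2)cc1`: 79900 nM

Going by the values given here, in a functional assay on A549 cells (Homo sapiens) for cytotoxicity, read by MTT assay, with a stated time of 48 h (on this read-out higher numbers stand for weaker inhibition and lower numbers for stronger inhibition), compound 1 has no single number, so it cannot be placed on the read-out; compound 2, the only measured compound with a result, gives 79900 nM in this assay. The step to follow goes from compound 1 to the unmeasured compound 3, `COC(=O)c1ccc(-n2cc(CCCOS(=O)(=O)c3ccc(C)cc3)nn2)cc1`. The change is methyl in place of phenyl on an aromatic carbon. Among the compounds with values here, no step between measured compounds is available, so the size of this change in this assay cannot be read from any pair of numbers; the expectation is that it stays within the scatter or shifts only modestly, in no firm direction. Compound 3 is expected to give an estimated 70000 nM in this assay, with a range of 25000 nM to 200000 nM, leaning on the weak value of compound 2, which gives 79900 nM.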

Compound 3, half-maximal inhibitory concentration: > 100000 nM
Compound 3 ended at the assay's limit; the forecaster's own chance of this, stated with the estimate: 30%; middle value at least 1.4-fold (0.15 log units) away from the limit.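

In this assay compound 3 gives > 100000 nM, which is a limit of the assay and not a number. Methoxycarbonyl in place of methyl on an aromatic carbon is the first change here whose size can be given at all, and it amounts to an at least 1.2-fold higher number from compound 2 to compound 3 (0.09 log units; that floor lies within the scatter). Only this floor can be stated, and the true step could be larger, because compound 3 sits at the limit: the limit of > 100000 nM in this assay, at which 1 of the 3 values shown sits.

From the compounds shown here alone, compound 1 has no number, so the step that swaps its phenyl for methyl cannot be read, and what phenyl does at this position stays unknown. Also open, going by these compounds, is whether a carboxylic acid or an amine in place of methoxycarbonyl would bring the reading well inside the measurable range.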